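A few compounds are considered here, and "the series" means these few. Any claim that something is new, unique, unknown or untested is made for them only; others in the source may bear on it.

Working notes on the sulfonyl series. All members share one core and differ only in the group on the sulfonyl sulfur. Compound 1 `COc1cccc(S(=O)(=O)c2ccccc2Cc2c3c(n(CC(=O)O)c2C)CCNC3=O)c1` gives 12 nM in a functional assay on CHO.K1 cells for antagonist activity at prostaglandin D2 receptor 2 (Homo sapiens), read by GTPgammaS binding, with a stated time of 1 h; a lower number here means a stronger inhibitor, a higher number a weaker inhibitor. Compound 2 `Cc1c(Cc2ccccc2S(=O)(=O)c2ccc(F)cc2)c2c(n1CC(=O)O)CCNC2=O` gives 3.3 nM in this assay. Compound 3 `Cc1c(Cc2ccccc2S(=O)(=O)C2CCCCC2)c2c(n1CC(=O)O)CCNC2=O` gives 28 nM in this assay, the highest of the three numbers: a 2.3-fold higher number from compound 1 to compound 3 (0.37 log units; beyond the scatter) and an 8.5-fold higher number from compound 2 to compound 3 (0.93 log units; beyond the scatter), while between the two aryl members a 3.6-fold lower number from compound 1 to compound 2 (0.56 log units; beyond the scatter). Compound 4 `Cc1c(Cc2ccccc2S(=O)(=O)N2CCOCC2)c2c(n1CC(=O)O)CCNC2=O` has not yet been measured in this assay. It differs from compound 3 in one place: morpholin-4-yl in place of cyclohexyl on a sulfonyl sulfur. The two measured steps that reach compound 3 are the ones that bear on this change, since both exchange the group on the same sulfonyl sulfur, and both are modest in size. Neither of them, however, enters a six-membered non-aromatic ring with hetero atoms, so they give a scale for the size of a step at this position but no direction for it. A modest step in either direction, or none beyond the scatter, is therefore expected. Compound 4 is estimated at 40 nM in this assay, with a range from 12 nM to 150 nM, which is expected to mean a 1.4-fold higher number from compound 3 to compound 4 (0.15 log units; within the scatter).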

Compound 4, half-maximal inhibitory concentration: 22 nM
For compound 4 the middle estimate is 1.8-fold (0.26 log units) above the measured one; low and high end bracket the measured number.
By their numbers in this assay, from the lowest: compound 2; then compounds 1, 4 and 3 (each within the scatter of the next, the first and the last beyond it).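

At the sulfonyl sulfur, a six-membered non-aromatic ring with 2 hetero atoms and 1 hydrogen-bond acceptor now stands where the ring of carbon only stood, and a 1.3-fold lower number from compound 3 to compound 4 (0.10 log units; within the scatter) in this assay shows no change beyond the scatter, so for this pair, swapping the carbon-only ring for morpholin-4-yl does not register in the read-out. Set against the aryl members, morpholin-4-yl gives a 1.8-fold higher number from compound 1 to compound 4 (0.26 log units; within the scatter), also within the scatter, but a 6.7-fold higher number from compound 2 to compound 4 (0.82 log units; beyond the scatter), which leaves compound 2 with its 4-fluorophenyl group as the strongest inhibitor of the four, its steps to all the others being beyond the scatter. Nothing shown explains why the 4-fluorophenyl group stands apart or why the two saturated rings read alike.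

The compounds shown leave open whether a ring carrying a basic amine, such as piperazin-1-yl, or a simple piperidin-1-yl would also stay level with compound 4. They also leave open whether a fluorine or a carboxylic acid placed on the saturated ring would bring the number closer to that of compound 2.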